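Replacing a Nitrile With Fluorine on the Shared Core

The compounds below may be only part of what the source reports. "The series", "measured", "known", "first", "only" and "open" are said of these compounds alone.

Compound 1 `Cn1c(CN2CCN(c3nc(Cl)ccc3C(F)(F)F)CC2)nc2cc(C#N)ccc21` gives 50.1 nM in an assay on CHO cells with metabotropic glutamate receptor 2 (Homo sapiens) as the target, read by FLIPR (on this read-out higher numbers stand for an effect only at larger amounts of compound and lower numbers for an effect already at smaller amounts), the lowest of the three numbers recorded. Compound 3 `Cn1c(CN2CCC(c3ccccc3F)CC2)nc2ccccc21` gives 126 nM in this assay, a gap beyond the usual scatter, and compound 2 `FC(F)(F)c1ccc(Cl)nc1N1CCN(Cc2nc3ccccc3[nH]2)CC1` gives 12600 nM in this assay, well above both. Compound 4 `Cn1c(CN2CCN(c3nc(Cl)ccc3C(F)(F)F)CC2)nc2cc(F)ccc21` has not yet been measured. It differs from compound 1 in a single place: fluoro in place of cyano on an aromatic carbon. For the measured compounds named here, no measured pair shows this change, so its size is uncertain; the account expects a modest loss for compound 4, the step of a 3.0-fold higher number from compound 1 to compound 4 (0.48 log units; beyond the scatter) running toward higher numbers but staying close to the scatter. Compound 4 is therefore estimated at 150 nM in this assay, with a range from 50 nM to 500 nM.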

Compound 4, half-maximal effective concentration: 200 nM
Compound 4: the middle estimate sits 1.3-fold (0.12 log units) below what was measured, and the stated range covers the measured number.
By their numbers in this assay, from the lowest: compound 1; then compounds 3 and 4 (each within the scatter of the next); then compound 2.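

On the shared core, fluoro in place of cyano on this aromatic carbon gives a 4.0-fold higher number from compound 1 to compound 4 (0.60 log units; beyond the scatter) in this assay, a modest step. The cyano group is therefore not indispensable at this position, since a single fluoro atom leaves the number far closer to that of compound 1 than to that of compound 2. Nothing available here accounts for the size of this step. Still open, on these data alone, is how a methoxy group, an amine or a carboxylic acid on this carbon would compare with cyano and fluoro.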